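The compounds below may be only part of what the source reports. "The series", "measured", "known", "first", "only" and "open" are said of these compounds alone.

In a functional assay on J774 cells (Mus musculus) for cytotoxicity, read by resazurin assay (a lower number here means a stronger inhibitor, a higher number a weaker inhibitor), compound 1 (`OCCCCCC(O)c1ccc(-c2ccccc2)cc1`) gives 22000 nM and compound 2 (`OCCCCCC(O)c1ccc(-c2ccc(O)cc2)cc1`) gives 15000 nM. For the measured compounds named here, these are the only two numbers so far, and compound 2 stands within the scatter of compound 1. Compound 3 (`CSc1ccc(-c2ccc(C(O)CCCCCO)cc2)cc1`) has methylsulfanyl in place of hydroxy on an aromatic carbon. Going by the values given here, the one measured step that bears on this place, a 1.5-fold lower number from compound 1 to compound 2 (0.17 log units; within the scatter), is small, so no step beyond the scatter is expected in this assay. The expected step is a 1.1-fold lower number from compound 2 to compound 3 (0.03 log units; within the scatter). For compound 3 the estimate is 14000 nM, with an expected range of 6000 nM to 30000 nM.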

Compound 3, half-maximal inhibitory concentration: 24000 nM
Beside the measured number, compound 3's estimate is 1.7-fold (0.23 log units) below it; the range from low to high includes it.
By their numbers in this assay, from the lowest: compounds 2, 1 and 3 (each within the scatter of the next).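

At this place, on an aromatic carbon para to a large group, this assay does not separate methylsulfanyl from hydroxy (a 1.6-fold higher number from compound 2 to compound 3 (0.20 log units; within the scatter)) or from hydrogen (a 1.1-fold higher number from compound 1 to compound 3 (0.04 log units; within the scatter)). Both steps lie within the scatter, although hydroxy counts one hydrogen-bond donor and methylsulfanyl none. Nothing measured here offers an explanation for this result. The compounds shown leave open whether an amine or a carboxylic acid at this place would give a step beyond the scatter. They also leave open what a longer chain would do.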